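This account rests on a few compounds, and the source may have more. Where it says the series, first, only, none or still open, it means among the compounds named here.

Two compounds share one core and differ only in the ring attached to the saturated chain carbon three bonds along the chain from an oxygen on an aromatic ring. Compound 1 `COc1cc2c(Oc3ccc(NC(=O)C4(c5nnc(-c6ccc(F)cc6)o5)CC4)cc3F)ccnc2cc1OCCCN1CCN(C)CC1` carries a 4-methylpiperazin-1-yl ring there, and in a functional assay on HT-29 cells (Homo sapiens) for antiproliferative activity, read by MTT assay, with a stated time of 72 h (on this read-out higher numbers stand for weaker inhibition and lower numbers for stronger inhibition), compound 1 gives 1050 nM. Compound 2 `COc1cc2c(Oc3ccc(NC(=O)C4(c5nnc(-c6ccc(F)cc6)o5)CC4)cc3F)ccnc2cc1OCCCN1CCC(C)CC1` carries a 4-methylpiperidin-1-yl ring instead, and in this assay compound 2 gives 442 nM, the lower of the two numbers; the step of a 2.4-fold lower number from compound 1 to compound 2 (0.38 log units; beyond the scatter) is modest but beyond the scatter. Compound 3 `COc1cc2c(Oc3ccc(NC(=O)C4(c5nnc(-c6ccc(F)cc6)o5)CC4)cc3F)ccnc2cc1OCCCN1CCCCC1` takes one further step: hydrogen in place of methyl on a saturated ring carbon, which turns the 4-methylpiperidin-1-yl ring into a plain piperidin-1-yl ring. Within the data shown here, no measured pair shows this kind of change; the only known step, a 2.4-fold lower number from compound 1 to compound 2 (0.38 log units; beyond the scatter), replaces one ring with another ring and so speaks only loosely to the loss of a methyl. With nothing pointing clearly either way, the expected step of a 1.2-fold higher number from compound 2 to compound 3 (0.07 log units; within the scatter) is small and may well fall within the scatter. Compound 3 is therefore estimated at 520 nM in this assay, with a likely range from 220 nM to 1200 nM.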

Compound 3, half-maximal inhibitory concentration: 1030 nM
The estimate for compound 3 lay 2.0-fold (0.30 log units) below the measured number, and the stated range covers the measured number.
By their numbers in this assay, from the lowest: compound 2; then compounds 3 and 1 (each within the scatter of the next).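

In this assay, taking the methyl off the 4-methylpiperidin-1-yl ring does not leave the number unchanged: the switch to piperidin-1-yl gives a 2.3-fold higher number from compound 2 to compound 3 (0.37 log units; beyond the scatter), so this one carbon, three ring bonds from the ring nitrogen, makes a measurable difference at this position. The plain piperidin-1-yl ring and the 4-methylpiperazin-1-yl ring cannot be told apart here, with a 1.0-fold lower number from compound 1 to compound 3 (0.01 log units; within the scatter), which means that the earlier 2.4-fold lower number from compound 1 to compound 2 (0.38 log units; beyond the scatter) cannot be credited to the piperidine ring alone and appears only when the methyl is present as well. Nothing available explains why the methyl matters in this way.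

From the compounds shown here alone, with a single methyl example, it remains open whether a larger alkyl group such as ethyl or isopropyl on that same ring carbon would lower the number further, or whether a hydroxyl group or a fluorine there would keep any of the difference. Going by these compounds, it is also open how a morpholin-4-yl ring or a dimethylamino group would compare at the end of the same chain.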